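Methoxy for Hydroxy on the Benzylamine Aryl Ring

The compounds below may be only part of what the source reports. "The series", "measured", "known", "first", "only" and "open" are said of these compounds alone.

compound 1 `O=C(O)CCc1ccc(NCc2ccc(Cl)cc2)cc1` — 1000 nM
compound 2 `O=C(O)CCc1ccc(NCc2ccc(O)cc2)cc1` — < 31700 nM

In a functional assay for agonist activity at Free fatty acid receptor 1 (Homo sapiens) (a lower number here means that less compound is needed, a higher number that more compound is needed for the effect), compound 1 gives 1000 nM. For compound 2 this assay reports only a limit, < 31700 nM, not a number. The step from compound 1 to compound 2, a step that the limit leaves unreadable from compound 1 to compound 2, has no readable size because the limit of < 31700 nM in this assay, at which 1 of the 2 values shown sits, sits at one end of it. Compound 3 `COc1ccc(CNc2ccc(CCC(=O)O)cc2)cc1` differs from compound 2 by methyl in place of hydrogen on an oxygen on an aromatic ring. Within the data shown here, no measured step covers this change, and the one step measured lacks a readable size, so the data give no direction to expect. Compound 3 is expected to give 1500 nM in this assay, between 300 nM and 8000 nM. This estimate is expected to mean a step that the limit leaves unreadable from compound 2 to compound 3.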

Compound 3, half-maximal effective concentration: 1260 nM
Beside the measured number, compound 3's estimate is 1.2-fold (0.08 log units) above it; the measured number falls inside the stated range.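

In this assay, swapping the chloro for a methoxy gives a 1.3-fold higher number from compound 1 to compound 3 (0.10 log units; within the scatter), so the assay does not tell these two groups apart at this place. This is the only readable step among the compounds shown. The two steps that involve compound 2 cannot be read, because its value is only a limit: the limit of < 31700 nM in this assay, at which 1 of the 3 values shown sits.

As far as these compounds go, how the hydroxy of compound 2 compares with methoxy or chloro therefore remains open. Also open, from the compounds shown here alone, is whether an amine or ethoxy on the same aromatic carbon would give a value like those of compound 1 and compound 3.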